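The source may report more compounds than this note shows. Statements on the series, on what has been measured and on what is new or still open speak of the compounds shown alone.

Measured compounds in a functional assay on microsomes for inhibition, with a stated time of 1 h; a higher number here means a weaker inhibitor, a lower number a stronger inhibitor:
compound 1 `Cn1c(NN)nc(-c2ccc(Cl)cc2)c(C#N)c1=O` gives 46 ug/mL
compound 2 `CN(C)c1ccc(-c2nc(NN)n(C)c(=O)c2C#N)cc1` gives 63 ug/mL
compound 3 `CCOC(=O)c1cnn(-c2nc(-c3ccccc3O)c(C#N)c(=O)n2C)c1N` gives 57 ug/mL

Compound 3 stands second highest of the three numbers, but all three lie within the scatter of one another: compound 2 is nearest to it and compound 1 furthest, neither separated from it by more than the scatter.

Compound 4 `CCOC(=O)c1cnn(-c2nc(-c3cccc(OC)c3OC)c(C#N)c(=O)n2C)c1N` is not yet measured in this assay. It differs from compound 3 in one place: 2,3-dimethoxyphenyl in place of 2-hydroxyphenyl on an aromatic carbon. Among the compounds with values here, the only measured step that bears on this change is a 1.4-fold higher number from compound 1 to compound 2 (0.14 log units; within the scatter), where one group on the aryl ring is exchanged for another on the shared core and the number stays within the scatter. Within the data shown here, no measured pair exchanges 2-hydroxyphenyl for 2,3-dimethoxyphenyl, so the expectation rests on that single step alone. The step from compound 3 to compound 4 is therefore expected to be a 1.1-fold higher number from compound 3 to compound 4 (0.02 log units; within the scatter), with no direction beyond the scatter. Compound 4 is estimated at 60 ug/mL in this assay, with a range from 30 ug/mL to 120 ug/mL.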

Compound 4, half-maximal inhibitory concentration: 57 ug/mL
Beside the measured number, compound 4's estimate is 1.1-fold (0.02 log units) above it; the range from low to high includes it.
By their numbers in this assay, from the lowest: compounds 1, 3, 4 and 2 (each within the scatter of the next).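

In this assay, 2,3-dimethoxyphenyl in place of 2-hydroxyphenyl on the aromatic carbon ortho to a cyano group gives no change at the digits printed from compound 3 to compound 4 (within the scatter). The earlier step changed a group on the aryl ring only on the core of compound 1, whereas this step is a one-place change on the core of compound 3, and it shows that this exchange, which removes the hydroxyl and brings in two methoxy groups, leaves the number within the scatter. Nothing on hand gives a reason for this result.

Whether the hydroxyl loss and the two methoxy groups each leave the number within the scatter on their own stays open, as 2-methoxyphenyl is not among the compounds shown. Also open, from the compounds shown here alone, is whether an amine, a carboxylic acid or a longer alkoxy chain such as butoxy on this aryl ring would move the number beyond the scatter.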